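The source may report more compounds than this note shows. Statements on the series, on what has been measured and on what is new or still open speak of the compounds shown alone.

Compound 1, `O=C(Nc1ccc(Cl)cc1CN1C(=O)c2ccccc2C1=O)c1ccccc1[N+](=O)[O-]`, in an assay on CHO cells for positive allosteric modulation of metabotropic glutamate receptor 5 (Rattus norvegicus), read by FLIPR (a lower number here means that less compound is needed, a higher number that more compound is needed for the effect), gives < 1000 nM, which is a limit of the assay and not a number.
Compound 2, `O=C(Nc1ccc(Cl)cc1CN1C(=O)c2ccccc2C1=O)c1cccnc1`, in this assay gives < 1000 nM, again a limit.
Compound 3, `O=C(Nc1ccc(Cl)cc1CN1C(=O)c2ccccc2C1=O)c1ncccn1`, in this assay gives < 1000 nM, also a limit.

All three share one core and differ only in the group on the carbonyl carbon. Because every value shown sits at the limit of < 1000 nM in this assay, at which 3 of the 3 values shown sit, none of the steps between them can be read: a step that the two limits leave unreadable from compound 1 to compound 2, a step that the two limits leave unreadable from compound 1 to compound 3 and a step that the two limits leave unreadable from compound 2 to compound 3 are all unreadable in size. Compound 3 therefore stands at the limit, with the two other values at the same limit beside it.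

Compound 4, `O=C(Nc1ccc(Cl)cc1CN1C(=O)c2ccccc2C1=O)C1CCCCC1`, differs from compound 3 by cyclohexyl in place of pyrimidin-2-yl on a carbonyl carbon. The two measured steps that change the same position, from compound 1 to compound 3 and from compound 2 to compound 3, bear on this change, but both are unreadable, so no direction or size beyond the scatter can be drawn from them.

Compound 4 is estimated to give 300 nM in this assay, expected to lie between 40 nM and 2500 nM. The step this estimate implies, a step that the limit leaves unreadable from compound 3 to compound 4, is an expectation only.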

Compound 4, half-maximal effective concentration: < 1000 nM
Compound 4: no number, only a limit (the forecaster's own chance of this, stated with the estimate: 55%); the middle value is on the limit's open side.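

Compound 4 also gives only a limit and not a number in this assay, so its steps to compound 1, compound 2 and compound 3 cannot be read, because all four compounds sit at the same limit: the limit of < 1000 nM in this assay, at which 4 of the 4 values shown sit.

The compounds shown leave open how far apart these four truly lie, and whether changing the group on the carbonyl carbon alters the concentration needed at all.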